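A few compounds are considered here, and "the series" means these few. Any claim that something is new, unique, unknown or untested is made for them only; others in the source may bear on it.

Compound 2 `CCC1(c2ccccc2)CC(=O)C(C(CC(=O)c2ccc(-c3ccc(Br)cc3)cc2)c2ccccc2)=C(O)O1` is measured in a functional assay on A549 cells (Homo sapiens) for inhibition, with a stated time of 72 h (on this read-out higher numbers stand for weaker inhibition and lower numbers for stronger inhibition), where compound 2 gives 8130 nM. For the measured compounds named here, its only measured neighbour is compound 1 `CC1(c2ccccc2)CC(=O)C(C(CC(=O)c2ccc(-c3ccc(Br)cc3)cc2)c2ccccc2)=C(O)O1`, which in this assay gives 9180 nM; the two numbers sit within the usual scatter of each other, so compound 2 cannot be set apart from compound 1 on this read-out. Going by the values given here, the one step recorded so far, a 1.1-fold lower number from compound 1 to compound 2 (0.05 log units; within the scatter), extends the substituent on the saturated ring carbon by one carbon and leaves the number essentially unchanged.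

Compound 3 `CCCC1(c2ccccc2)CC(=O)C(C(CC(=O)c2ccc(-c3ccc(Br)cc3)cc2)c2ccccc2)=C(O)O1` takes the same kind of change one bond further out: methyl in place of hydrogen on a saturated chain carbon, two bonds along the chain from a saturated ring carbon. Among the compounds with values here, the single step that bears on it, a 1.1-fold lower number from compound 1 to compound 2 (0.05 log units; within the scatter), was within the scatter, which gives no ground to expect a change beyond the scatter here either. The expected step is a 1.1-fold lower number from compound 2 to compound 3 (0.04 log units; within the scatter). Compound 3 is therefore estimated to give 7500 nM, with a range from 3800 nM to 15000 nM.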

Compound 3, half-maximal inhibitory concentration: > 10000 nM
Compound 3 gave a limit, no number; the forecaster's own chance of this, stated with the estimate: 5%; at least 1.3-fold (0.12 log units) between middle value and limit.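

In this assay compound 3 gives > 10000 nM, which is a limit of the assay and not a number: the limit of > 10000 nM in this assay, at which 1 of the 3 values shown sits. Set against the earlier compounds, the ethyl to propyl change gives an at least 1.2-fold higher number from compound 2 to compound 3 (0.08 log units; that floor lies within the scatter), and the whole replacement of methyl by propyl gives an at least 1.0-fold higher number from compound 1 to compound 3 (0.03 log units; that floor lies within the scatter). Both steps are floors within the scatter, so while the methyl to ethyl change had a size that could be read, this further change at the same position has only a lower bound, and any real loss of inhibition remains unproven.

The compounds shown leave open how far compound 3 lies past its limit. They also leave open whether an amine or a carboxylic acid in place of the propyl would return a number in this assay.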